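This account rests on a few compounds, and the source may have more. Where it says the series, first, only, none or still open, it means among the compounds named here.

Measured set in a functional assay (trachea) with Cavia porcellus as the target; on this read-out lower numbers stand for an effect already at smaller amounts and higher numbers for an effect only at larger amounts of compound:
- compound 1, `C=CCn1c(=O)c2[nH]cnc2n(CCC)c1=O`: 1600 nM
- compound 2, `CCCn1c(=O)n(CC(=O)O)c(=O)c2[nH]cnc21`: 41000 nM
- compound 3, `CCCn1c(=O)n(CCOCC)c(=O)c2[nH]cnc21`: 70 nM

Compound 2 stands at the highest number of the three in this assay. Its nearest neighbour is compound 1, separated by a 26-fold higher number from compound 1 to compound 2 (1.41 log units; beyond the scatter); the widest gap runs to compound 3, a 590-fold lower number from compound 2 to compound 3 (2.77 log units; beyond the scatter). Compound 4, `CCCn1c(=O)n(CCCOC)c(=O)c2[nH]cnc21`, is not yet measured. It arises from compound 2 by 2-methoxyethyl in place of carboxy on a saturated chain carbon bound to an aromatic nitrogen.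

The most direct precedent is the step already seen in this assay, a 590-fold lower number from compound 2 to compound 3 (2.77 log units; beyond the scatter), where carboxy leaves the same saturated chain carbon bound to an aromatic nitrogen and an ether-bearing chain, ethoxymethyl, enters. The 2-methoxyethyl entering in compound 4 is a close relative of that ethoxymethyl, an ether chain of like make-up. The other two steps frame the picture: a 23-fold lower number from compound 1 to compound 3 (1.36 log units; beyond the scatter) places the ether chain far on the low side of vinyl, while a 26-fold higher number from compound 1 to compound 2 (1.41 log units; beyond the scatter) places carboxy far on the high side. Both are well beyond the scatter. A large drop in this assay is therefore expected for compound 4, of a size comparable to the precedent, a 410-fold lower number from compound 2 to compound 4 (2.61 log units; beyond the scatter). Compound 4 is estimated to land near 100 nM, with an expected range from 30 nM to 350 nM.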

Compound 4, half-maximal effective concentration: 2900 nM
Estimate against measurement, compound 4: 29-fold (1.46 log units) below; the whole stated range lies below it.
By their numbers in this assay, from the lowest: compound 3; then compounds 1 and 4 (each within the scatter of the next); then compound 2.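

In this assay the ether chain does not reproduce the large drop seen on leaving carboxy: 2-methoxyethyl in place of carboxy still lowers the number (a 14-fold lower number from compound 2 to compound 4 (1.15 log units; beyond the scatter)), but far less than ethoxymethyl does in the same place (a 590-fold lower number from compound 2 to compound 3 (2.77 log units; beyond the scatter)). This position therefore separates two ether chains of like make-up, with methoxymethyl in place of ethoxy on a saturated chain carbon, two bonds along the chain from an aromatic nitrogen, giving a large step (a 41-fold higher number from compound 3 to compound 4 (1.62 log units; beyond the scatter)), so an ether oxygen in the chain does not by itself set the result. The 2-methoxyethyl chain also cannot be told apart from vinyl in this assay (a 1.8-fold higher number from compound 1 to compound 4 (0.26 log units; within the scatter)), and no measurement at hand accounts for this sensitivity to the chain.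

The compounds shown leave open how a longer ether chain, a hydroxy group or an amine at the end of this chain would read in this assay and whether either ether chain keeps its place relative to the other. They also leave open whether the same order holds when the propyl group on the shared core is replaced by an ethyl or butyl chain.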